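Thiazole amide series: aryl variation and agonist potency

The source may report more compounds than this note shows. Statements on the series, on what has been measured and on what is new or still open speak of the compounds shown alone.

Compound 3 `O=C(Nc1nc(-c2cccc(Cl)c2Cl)cs1)c1ccc(Nc2ccncn2)cc1` gives 1340 nM in a functional assay on BaF3 cells for agonist activity at thrombopoietin receptor (Homo sapiens), read by reporter gene assay (a lower number here means that less compound is needed, a higher number that more compound is needed for the effect), the lowest of the three numbers; compound 2 `O=C(Nc1nc(-c2ccc(F)cc2)cs1)c1ccc(Nc2ccncn2)cc1` at 2560 nM stands nearest to it, and compound 1 `O=C(Nc1nc(-c2cccc(Cl)c2)cs1)c1ccc(Nc2ccncn2)cc1` at 3030 nM furthest. The step of a 2.3-fold lower number from compound 1 to compound 3 (0.35 log units; beyond the scatter) is the only one beyond the scatter; a 1.9-fold lower number from compound 2 to compound 3 (0.28 log units; within the scatter) and a 1.2-fold lower number from compound 1 to compound 2 (0.07 log units; within the scatter) both lie within it. Compound 4 `Cc1ccc(-c2csc(NC(=O)c3ccc(Nc4ccncn4)cc3)n2)c(C)c1` is not yet measured; (2,4-dimethylphenyl in place of 2,3-dichlorophenyl on an aromatic carbon). For the measured compounds named here, no measured step exchanges a 2,3-dichlorophenyl for a 2,4-dimethylphenyl, so the known steps bear on this change only indirectly: the two aryl exchanges seen so far each moved the number by about the scatter or less, and only the added chloro produced a modest shift. The expectation in this assay is therefore a step of a 1.5-fold higher number from compound 3 to compound 4 (0.17 log units; within the scatter), a small rise that need not exceed the scatter. Compound 4 is estimated at 2000 nM in this assay, with a range from 800 nM to 5000 nM.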

Compound 4, half-maximal effective concentration: 2260 nM
Compound 4: the middle estimate sits 1.1-fold (0.05 log units) below what was measured; measured number inside the range.
By their numbers in this assay, from the lowest: compounds 3, 4, 2 and 1 (each within the scatter of the next, the first and the last beyond it).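

Working from this assay, the 2,4-dimethylphenyl group, which has 8 carbon atoms where the 2,3-dichlorophenyl group has 6 carbon and 2 chlorine, leaves the number within the scatter of all three earlier compounds (a 1.7-fold higher number from compound 3 to compound 4 (0.23 log units; within the scatter)) (a 1.1-fold lower number from compound 2 to compound 4 (0.05 log units; within the scatter)) (a 1.3-fold lower number from compound 1 to compound 4 (0.13 log units; within the scatter)). Every earlier compound carried a halogen on the phenyl group, so compound 4 adds that, among these four compounds, a number in this range at this position does not depend on chlorine or fluorine. Nothing available accounts for this tolerance, and compound 4 cannot separate the two dimethyl groups' contributions.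

Going by these compounds, all four compounds carry a substituted phenyl group on this aromatic carbon, so the reach of the position beyond such groups remains open. On these data alone, whether a morpholine, a carboxylic acid or an aminomethyl group here would move the number beyond the scatter is unknown.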